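From 4-fluorophenyl to 3,5-dimethylphenyl on a sulfur

The source may hold more compounds than are shown below. What is called first, only, known or untested is meant among the compounds shown, and "the series" means these compounds.

Compound 1 `Nc1ccccc1NC(=O)c1ccc(CSc2cccc(F)c2)cc1`: 72.7%
Compound 2 `Nc1ccccc1NC(=O)c1ccc(CSc2ccc(F)cc2)cc1`: 44.5%

Both numbers come from a functional assay on A549 cells (Homo sapiens) for inhibition, read by CCK-8 assay, with a stated time of 72 h, tested at 8 uM; a higher number here means more inhibition of growth at the concentration tested, a lower number less inhibition of growth. Of the two, compound 2 stands lower, at 44.5%, and the gap to compound 1 lies beyond the usual scatter. The next molecule, compound 3 `Cc1cc(C)cc(SCc2ccc(C(=O)Nc3ccccc3N)cc2)c1`, keeps the shared core and changes only the group on the sulfur, with 3,5-dimethylphenyl in place of 4-fluorophenyl (3,5-dimethylphenyl in place of 4-fluorophenyl on a sulfur).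

For the measured compounds named here, only one measured step bears on this change: a number 28.2 percentage points lower from compound 1 to compound 2 (beyond the scatter). That step, beyond the scatter, put 4-fluorophenyl in place of 3-fluorophenyl, so the group on the sulfur can clearly alter the result in this assay. Going by the values given here, still, no measured compound carries methyl groups, and two compounds establish no rule. The new group does share a 3 in its name with the group of compound 1, which gives 72.7%, so a modest rise is expected, though with much uncertainty. The expected change is a number 10.5 percentage points higher from compound 2 to compound 3 (beyond the scatter). For compound 3 the estimated value is 55%, with an expected range from 30% to 80%.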

Compound 3, percent growth inhibition at one concentration: 78.5%
Compound 3: middle estimate off by 23.5 percentage points, on the low side, and the stated range covers the measured number.
By their numbers in this assay, from the lowest: compound 2; then compounds 1 and 3 (each within the scatter of the next).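

In this assay, the group on the sulfur does not need a fluorine to give a high number: with 3,5-dimethylphenyl in place of 4-fluorophenyl, the result is a number 34 percentage points higher from compound 2 to compound 3 (beyond the scatter), a large step that restores what the earlier change had lost. Set against 3-fluorophenyl, the same group gives a number 5.8 percentage points higher from compound 1 to compound 3 (within the scatter), so compound 1 and compound 3 cannot be told apart in this measurement, although one group carries a fluorine and the other carries two methyl groups. Across these three compounds, the two groups with a 3 in their names both give high numbers and 4-fluorophenyl alone stands low, but three compounds are too few to show whether the location of a group on the ring matters more than the kind of group.

Nothing measured here tells why the numbers move in this way. Still open, going by these compounds, is whether one methyl group, as in 3-methylphenyl, would be enough, and whether an amine or a carboxylic acid on this ring would keep the number high.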